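Methoxy for Methylsulfanyl: Compound 4 in Prospect

This account rests on a few compounds, and the source may have more. Where it says the series, first, only, none or still open, it means among the compounds named here.

Of the compounds shown here, three have been measured in a functional assay on CCRF-CEM cells (Homo sapiens) for cytotoxicity, read by MTT assay, with a stated time of 72 h; a lower number here means a stronger inhibitor of growth, a higher number a weaker inhibitor of growth. Compound 1 `COc1ccc(CNc2nc(SC)nc3ccccc23)cc1` gives 93700 nM, compound 2 `CSc1ccc(CNc2nc([SeH])nc3ccccc23)cc1` gives 71900 nM, and compound 3 `CSc1ccc(CNc2nc([Se]C)nc3ccccc23)cc1` gives 48700 nM, which stands at the low end of the three numbers, though its gaps to compound 2 and to compound 1 both lie within the scatter. Among the compounds with values here, the only single-point step seen so far, a 1.5-fold lower number from compound 2 to compound 3 (0.17 log units; within the scatter), was itself within the scatter. Compound 4 `COc1ccc(CNc2nc([Se]C)nc3ccccc23)cc1` differs from compound 3 as methoxy in place of methylsulfanyl on an aromatic carbon. Within the data shown here, no measured step bears on this exchange; compound 1 and compound 3 differ in two places, and their values show only a spread within the scatter. A change of no more than the scatter is therefore expected, a 1.1-fold higher number from compound 3 to compound 4 (0.05 log units; within the scatter). Compound 4 is estimated at 55000 nM, between 25000 nM and 120000 nM.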

Compound 4, concentration for 50% growth inhibition: > 100000 nM
Compound 4: no number, only a limit; the forecaster's own chance of this, stated with the estimate: 5%; middle value at least 1.8-fold (0.25 log units) away from the limit.
By their numbers in this assay, from the lowest: compounds 3, 2 and 1 (each within the scatter of the next). At a limit, above all of these: compound 4.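

In this assay compound 4 gives only a limit, not a number: the limit of > 100000 nM in this assay, at which 1 of the 4 values shown sits. Methoxy in place of methylsulfanyl, para to a large group, gives an at least 2.0-fold higher number from compound 3 to compound 4 (0.31 log units; beyond the scatter), so this position responds to the exchange by more than the scatter, which no earlier step showed. The group of carbon and selenium in place of the group of carbon and sulfur gives an at least 1.0-fold higher number from compound 1 to compound 4 (0.02 log units; that floor lies within the scatter), which fixes no size for that exchange. As far as these compounds go, how far either step truly reaches remains open. Also open, from the compounds shown here alone, is how an amine or a longer chain at this position would compare with methylsulfanyl.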